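Swapping the benzylamine arm in a shared solubility series

The source may report more compounds than this note shows. Statements on the series, on what has been measured and on what is new or still open speak of the compounds shown alone.

Compound 3 `COc1ccc(F)cc1CNCCCNc1ccnc2cc(Oc3ccc(C(C)(C)C)cc3)ccc12` sits level with its two relatives, compound 1 `COc1ccccc1Oc1ccc2c(NCCCNCc3ccco3)ccnc2c1` and compound 2 `Fc1ccc(Oc2ccc3c(NCCCNCc4ccco4)ccnc3c2)cc1`, in a physicochemical assay for solubility, with a stated time of 18 h, at pH 7.4; on this read-out lower numbers stand for lower solubility and higher numbers for higher solubility: compound 3 gives 14500 nM, compound 1 gives 14500 nM and compound 2 gives 14500 nM. Among the compounds with values here, the only measured step, no change at the digits printed from compound 1 to compound 2 (within the scatter), changes the aryl ether and not the amine arm, so nothing recorded bears directly on the move to compound 4 `CC(C)(C)c1ccc(Oc2ccc3c(NCCCNCc4ccco4)ccnc3c2)cc1`, which is furan-2-yl in place of 5-fluoro-2-methoxyphenyl on a saturated chain carbon bound to an amine nitrogen. With every measured compound at the same level, a shift beyond the scatter in this assay is not expected, and compound 4 is estimated at 14500 nM, within 7000 nM to 30000 nM, an expected step of no change at the digits printed from compound 3 to compound 4 (within the scatter).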

Compound 4, solubility: 14500 nM
The estimate for compound 4 equals the measured number at the digits printed, within the range that was stated.
By their numbers in this assay, from the lowest: compounds 1, 2, 3 and 4 (each within the scatter of the next).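

In this assay the amine arm now has a measured step, no change at the digits printed from compound 3 to compound 4 (within the scatter), for furan-2-yl in place of 5-fluoro-2-methoxyphenyl on a saturated chain carbon bound to an amine nitrogen. The aryl ether gains two further readings: no change at the digits printed from compound 2 to compound 4 (within the scatter) for tert-butyl in place of fluoro on an aromatic carbon, and no change at the digits printed from compound 1 to compound 4 (within the scatter) for 4-(tert-butyl)phenyl in place of 2-methoxyphenyl on an oxygen on an aromatic ring. No supporting data explain these results. On these data alone, whether a morpholine or a carboxylic acid at that chain position would shift the read-out from this shared level remains open.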